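This account rests on a few compounds, and the source may have more. Where it says the series, first, only, none or still open, it means among the compounds named here.

Compound 1 `c1ccc(Cc2ccc3c(NCCCNCc4ccco4)ccnc3c2)cc1`: 9.47
Compound 2 `COc1ccc(F)cc1CNCCCNc1ccnc2cc(Cc3ccccc3)ccc12`: 9.47
Compound 3 `COc1ccc(-c2ccc3c(NCCCNCc4ccco4)ccnc3c2)cc1`: 9.47

In a physicochemical assay for acid dissociation, compound 1 gives 9.47. Compound 2 carries the change (5-fluoro-2-methoxyphenyl in place of furan-2-yl on a saturated chain carbon bound to an amine nitrogen), and the step of no change at the digits printed from compound 1 to compound 2 (within the scatter) is flat, so in this assay compound 2 gives 9.47. The cores of compound 1 and compound 3 differ by 4-methoxyphenyl in place of benzyl on an aromatic carbon, and again the step of no change at the digits printed from compound 1 to compound 3 (within the scatter) is flat, so in this assay compound 3 gives 9.47. The three measured values stand level within the scatter of the method.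

Compound 4 `COc1ccc(-c2ccc3c(NCCCNCc4cc(F)ccc4OC)ccnc3c2)cc1` has not yet been measured. Within the data shown here, it differs from compound 3 by 5-fluoro-2-methoxyphenyl in place of furan-2-yl on a saturated chain carbon bound to an amine nitrogen, which is the same change as the one from compound 1 to compound 2, made at the same place. Because that earlier step no change at the digits printed from compound 1 to compound 2 (within the scatter) was flat on the core of compound 1, the corresponding step on the core of compound 3 is expected to be no change at the digits printed from compound 3 to compound 4 (within the scatter). On this basis compound 4 is expected to give 9.47 in this assay. For compound 4 the expected range runs from 9.17 to 9.77, allowing for the usual scatter of repeated measurements.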

Compound 4, acid dissociation constant: 9.47
Beside the measured number, compound 4's estimate shows no gap at the digits printed, and the stated range covers the measured number.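

In this assay the step of no change at the digits printed from compound 3 to compound 4 (within the scatter) reads the same as the step of no change at the digits printed from compound 1 to compound 2 (within the scatter) and so 5-fluoro-2-methoxyphenyl in place of furan-2-yl on a saturated chain carbon bound to an amine nitrogen stays flat on both cores, while the step of no change at the digits printed from compound 2 to compound 4 (within the scatter) matches the step of no change at the digits printed from compound 1 to compound 3 (within the scatter) for the other change. This shows that the two changes can be combined without a departure from the shared value in these four compounds, but as all the steps are flat, it shows only that a null result carries over between two cores and does not test whether a step of real size would carry, nor whether this one would hold on any other core. No measurement shown explains why the values stay level.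

The compounds shown leave open whether the values would stay level with a carboxylic acid or a second amine in place of the 5-fluoro-2-methoxyphenyl. They also leave open what a longer chain would do at the same place.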